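Methyl at the Hydroxyl-Bearing Carbon of Compound 2

The compounds below may be only part of what the source reports. "The series", "measured", "known", "first", "only" and "open" are said of these compounds alone.

Compound 1 `CCCCc1ccc2c(c1)C(=O)C(=O)N2` reaches only the limit > 10000 nM in a functional assay on HepG2 cells (Homo sapiens) for antiproliferative activity, read by MTT assay, with a stated time of 48 h; a lower number here means a stronger inhibitor, a higher number a weaker inhibitor; this is the limit of > 10000 nM in this assay, at which 1 of the 2 values shown sits. Within the data shown here, compound 2 `COc1ccc(CN2C(=O)C(O)c3cc(-c4ccc(OC)cc4)ccc32)cc1` gives the sole measured number in this assay, namely 700 nM. Compound 3 `COc1ccc(CN2C(=O)C(C)(O)c3cc(-c4ccc(OC)cc4)ccc32)cc1` differs from compound 2 by methyl in place of hydrogen on a saturated ring carbon. Among the measured compounds shown here, no step between measured compounds exists here, so the size of this change rests on the structural change alone. The expected step in this assay is a 1.1-fold higher number from compound 2 to compound 3 (0.06 log units; within the scatter), nothing beyond the scatter. Compound 3 is estimated at 800 nM, between 250 nM and 2500 nM.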

Compound 3, half-maximal inhibitory concentration: > 10000 nM
Compound 3: no number, only a limit; the forecaster's own chance of this, stated with the estimate: 5%; at least 12-fold (1.09 log units) between middle value and limit.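

In this assay, this saturated ring carbon proves far from indifferent to a small change: methyl in place of hydrogen gives an at least 14-fold higher number from compound 2 to compound 3 (1.15 log units; beyond the scatter). One added carbon is thus enough to lose the measurable activity of compound 2 at this position. The value of compound 3 is a limit of the assay, not a number: the limit of > 10000 nM in this assay, at which 2 of the 3 values shown sit.

The compounds shown leave open how an ethyl group or an amine on this carbon would read. They also leave open whether the hydroxyl itself matters, and how far the true value of compound 3 lies past the limit.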